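The source may hold more compounds than are shown below. What is called first, only, known or untested is meant among the compounds shown, and "the series" means these compounds.

Measured in an assay on HEK293 cells for agonist activity at transient receptor potential cation channel subfamily M member 8 (Homo sapiens), read by fluorescence and calcium flux, with a stated time of 15 min (a lower number here means that less compound is needed, a higher number that more compound is needed for the effect), so far: compound 1 `CCN(Cc1cccs1)C(=O)COc1ccc(C)cc1` gives 8 nM; compound 2 `CCN(Cc1cccs1)C(=O)COc1cc(C)ccc1O` gives 24 nM; compound 3 `CCN(Cc1cccs1)C(=O)COc1ccc(C)cc1O` gives 8 nM.

Compound 2 has the highest of the three numbers; its value and that of compound 3 show the same atoms joined differently, and the difference between the two cores is not broken down here. From compound 3 to compound 1, (hydrogen in place of hydroxy on an aromatic carbon), the step is no change at the digits printed from compound 3 to compound 1 (within the scatter). The same kind of change leads from compound 2 to compound 4 `CCN(Cc1cccs1)C(=O)COc1cccc(C)c1`, (hydrogen in place of hydroxy on an aromatic carbon); here the place is para to a methyl group, whereas in compound 3 it is meta to a methyl group. Because the earlier step of no change at the digits printed from compound 3 to compound 1 (within the scatter) stayed within the scatter, compound 4 is expected to sit close to compound 2, with an estimated step of a 1.5-fold lower number from compound 2 to compound 4 (0.18 log units; within the scatter). In this assay compound 4 is estimated at 16 nM, between 5 nM and 50 nM.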

Compound 4, half-maximal effective concentration: 97 nM
The estimate for compound 4 lay 6.1-fold (0.78 log units) below the measured number; the measured number lies above the stated range.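

In this assay, hydrogen in place of hydroxy para to a methyl group gives a 4.0-fold higher number from compound 2 to compound 4 (0.61 log units; beyond the scatter). Among these compounds, the effect of this change therefore does not carry over from one core to the other: the same change on two cores in this assay, no change at the digits printed (within the scatter) from compound 3 to compound 1 and a 4.0-fold higher number (0.61 log units; beyond the scatter) from compound 2 to compound 4, 4.0-fold (0.61 log units) apart, beyond the scatter of two such steps These two pairs show only that the step depends on the core that carries it; they do not show why, and they offer no rule for any further core.

All four compounds carry a methyl group on the aromatic ring and have either hydroxy or hydrogen as the changing group. On these data alone, it remains open how the step would read with an amine or a carboxylic acid in place of the hydroxy, or with a longer chain in place of the methyl group.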